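Cinnamate series: carboxy in place of ethoxymethyl on the benzyl arm

A few compounds are considered here, and "the series" means these few. Any claim that something is new, unique, unknown or untested is made for them only; others in the source may bear on it.

Measured so far:
Compound 1, `COC(=O)/C=C/c1cccc(N(Cc2ccc(C(C)(C)C)cc2)C(=O)C2CCCCC2)c1`, gives only a limit in an assay on isolated protein with Bile acid receptor (Homo sapiens) as the target; on this read-out higher numbers stand for an effect only at larger amounts of compound and lower numbers for an effect already at smaller amounts: > 1000 nM.
Compound 2, `CCOC/C=C/c1ccc(CN(C(=O)C2CCCCC2)c2cccc(/C=C/C(=O)OC)c2)cc1`, gives in this assay a value of 198000 nM.

For the measured compounds named here, compound 2 carries the only number in this assay; the other value shown is a limit. The step from compound 1 to compound 2, a step that the limit leaves unreadable from compound 1 to compound 2, cannot be sized, because the limit of > 1000 nM in this assay, at which 1 of the 2 values shown sits, leaves it unreadable.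

Compound 3, `COC(=O)/C=C/c1cccc(N(Cc2ccc(/C=C/C(=O)O)cc2)C(=O)C2CCCCC2)c1`, is not yet measured. It differs from compound 2 by carboxy in place of ethoxymethyl on a double-bonded chain carbon bound to a double-bonded chain carbon. Going by the values given here, the one measured step on this arm of the molecule bears on it only in that it is unreadable, so no direction can be taken from it. For compound 3 in this assay, therefore, the expectation is a step of a 1.3-fold lower number from compound 2 to compound 3 (0.12 log units; within the scatter) that stays within the scatter. The estimated value for compound 3 is 150000 nM, with a range from 20000 nM to 1000000 nM.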

Compound 3, half-maximal effective concentration: > 1000 nM
Compound 3: a limit, no number; the forecaster's own chance of this, stated with the estimate: 40%; the middle value is on the limit's open side.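

Compound 3 gives only a limit, so no step joining it to compound 1 or compound 2 in this assay can be read, because of this: the limit of > 1000 nM in this assay, at which 2 of the 3 values shown sit.
Open remains how compound 1 and compound 3 stand against compound 2, and whether carboxy in place of ethoxymethyl shifts the read-out at all.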